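The source may report more compounds than this note shows. Statements on the series, on what has been measured and on what is new or still open speak of the compounds shown alone.

For the measured compounds named here, compound 3 `c1ccc2c(-c3cn4ccnc4c(-c4ccc5ncn(C6CCCCC6)c5c4)n3)cccc2c1` stands lowest of the three compounds measured so far in a functional assay on CCRF-CEM cells (Homo sapiens) for inhibition, read by sulforhodamine B assay, with a stated time of 48 h, tested at 10 uM; on this read-out higher numbers stand for more inhibition at the one concentration tested (going by the name of the read-out) and lower numbers for less inhibition: compound 3 gives 17.5%, whereas compound 1 `COc1ccc(-c2cn3ccnc3c(-c3ccc4ncn(C5CCCCC5)c4c3)n2)cc1` gives 93.3% and compound 2 `O=Cc1ccc(-c2cn3ccnc3c(-c3ccc4ncn(C5CCCCC5)c4c3)n2)cc1` gives 77.9%. Compound 4 `c1cn2cc(-c3ccsc3)nc(-c3ccc4ncn(C5CCCCC5)c4c3)c2n1` has not yet been measured. It differs from compound 3 in one place: thiophen-3-yl in place of naphthalen-1-yl on an aromatic carbon. Going by the values given here, two measured steps bear on this change, and both lead into compound 3: a number 75.8 percentage points lower from compound 1 to compound 3 (beyond the scatter) and a number 60.4 percentage points lower from compound 2 to compound 3 (beyond the scatter). In each, putting naphthalen-1-yl in place of 4-methoxyphenyl or 4-formylphenyl brought a large fall. Taking naphthalen-1-yl away again, now for thiophen-3-yl, is therefore expected to raise inhibition markedly, although thiophen-3-yl itself has no measured partner here, so the size is uncertain. Compound 4 is expected to reach 60%, within 25% to 90%, a step of a number 42.5 percentage points higher from compound 3 to compound 4 (beyond the scatter).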

Compound 4, a percentage reported as inhibition, at one concentration (the size of the read-out at that concentration, not a potency): 29.2%
Beside the measured number, compound 4's estimate is 30.8 percentage points above it, and the stated range covers the measured number.
By their numbers in this assay, from the lowest: compound 3; then compound 4; then compound 2; then compound 1.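

In this assay, replacing naphthalen-1-yl does not by itself restore inhibition: a number 11.7 percentage points higher from compound 3 to compound 4 (beyond the scatter) is only modest, whereas a number 48.7 percentage points lower from compound 2 to compound 4 (beyond the scatter) and a number 64.1 percentage points lower from compound 1 to compound 4 (beyond the scatter) are both large. For the compounds shown here, the loss at this position is therefore not tied to naphthalen-1-yl alone, since the high numbers so far belong only to 4-methoxyphenyl and 4-formylphenyl. No measurement here explains this difference.

On these data alone, it remains open whether an unsubstituted phenyl would keep the inhibition. The same applies to a phenyl carrying an amine or a carboxylic acid in place of methoxy or formyl.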